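Removing a second acetyl from a diterpenoid lactone

The source may report more compounds than this note shows. Statements on the series, on what has been measured and on what is new or still open speak of the compounds shown alone.

Compound 1 `C=C1CC[C@@H]2[C@](C)(COC(C)=O)[C@H](OC(C)=O)CC[C@@]2(C)[C@@H]1C/C=C1/C(=O)OC[C@H]1OC(C)=O` and compound 2 `C=C1CC[C@@H]2[C@](C)(CO)[C@H](OC(C)=O)CC[C@@]2(C)[C@@H]1C/C=C1/C(=O)OC[C@H]1OC(C)=O` were tested in a functional assay on ASK cells (Rattus norvegicus) for cytotoxicity, read by sulforhodamine B assay; on this read-out higher numbers stand for an effect only at larger amounts of compound and lower numbers for an effect already at smaller amounts. Compound 1 gives 11.4 uM, and compound 2 gives 11.5 uM; the step of a 1.0-fold higher number from compound 1 to compound 2 (0.00 log units; within the scatter) leaves compound 1 standing level with compound 2. Compound 3 `C=C1CC[C@@H]2[C@](C)(COC(C)=O)[C@H](O)CC[C@@]2(C)[C@@H]1C/C=C1/C(=O)OC[C@H]1OC(C)=O` carries the change (hydrogen in place of acetyl on an oxygen on a saturated carbon). Going by the values given here, the only step that bears on it, that from compound 1 to compound 2 with a 1.0-fold higher number from compound 1 to compound 2 (0.00 log units; within the scatter), was the same kind of change at another oxygen and stayed within the scatter, so no step beyond the scatter is expected for a 1.0-fold higher number from compound 1 to compound 3 (0.00 log units; within the scatter). Compound 3 is therefore estimated at 11.5 uM, within 6 uM to 23 uM.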

Compound 3, concentration for half-maximal effect: 16.3 uM
For compound 3 the middle estimate is 1.4-fold (0.15 log units) below the measured one; low and high end bracket the measured number.
By their numbers in this assay, from the lowest: compounds 1, 2 and 3 (each within the scatter of the next).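

In this assay, exchanging acetyl for hydrogen on this oxygen, on a saturated carbon whose other neighbour is a saturated ring carbon, gives a 1.4-fold higher number from compound 1 to compound 3 (0.16 log units; within the scatter). Alongside a 1.0-fold higher number from compound 1 to compound 2 (0.00 log units; within the scatter), this shows that the acetoxy to hydroxy change stays within the scatter at a second oxygen of compound 1, not only at the first. Nothing given here offers a reason for this.

Open, from the compounds shown here alone, is whether an amine or a longer ester chain at this position would move the number. Also open, going by these compounds, is what happens when the acetyl groups are lost together.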